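The source may hold more compounds than are shown below. What is called first, only, known or untested is meant among the compounds shown, and "the series" means these compounds.

Measured so far in a functional assay on L1210 cells (Mus musculus), read by MTT assay; a lower number here means a stronger inhibitor, a higher number a weaker inhibitor:
compound 1 `C=C[C@@]1(O)[C@@H](CO)O[C@@H](n2ccc(=O)[nH]c2=O)[C@@H]1O`: 148000 nM
compound 2 `CC[C@@]1(O)[C@@H](CO)O[C@@H](n2ccc(N)nc2=O)[C@@H]1O`: 269000 nM
compound 3 `C#C[C@]1(O)[C@H](O)[C@@H](CO)O[C@H]1n1ccc(N)nc1=O`: > 350000 nM

Compound 1 gives the lowest of the two numbers, but compound 2 sits within the scatter of it, so no order between the two can be read. For compound 3 the result in this assay is a limit and not a number: the limit of > 350000 nM in this assay, at which 1 of the 3 values shown sits. Compound 4 `CC#C[C@@]1(O)[C@@H](CO)O[C@@H](n2ccc(=O)[nH]c2=O)[C@@H]1O` is not yet measured. Compared with compound 1 it carries prop-1-yn-1-yl in place of vinyl on a saturated ring carbon. Within the data shown here, no measured pair isolates this change, so the expectation rests on compound 1 alone, and in this assay a step of no more than the scatter is expected, leaning toward a higher number. Compound 4 is expected to give 200000 nM, within 60000 nM to 600000 nM. The expected step is a 1.4-fold higher number from compound 1 to compound 4 (0.13 log units; within the scatter).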

Compound 4, half-maximal inhibitory concentration: 354000 nM
Beside the measured number, compound 4's estimate is 1.8-fold (0.25 log units) below it; the measured number falls inside the stated range.
By their numbers in this assay, from the lowest: compounds 1, 2 and 4 (each within the scatter of the next, the first and the last beyond it).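

Among these compounds, on the saturated ring carbon that bears vinyl in compound 1, the change to prop-1-yn-1-yl in this assay gives a 2.4-fold higher number from compound 1 to compound 4 (0.38 log units; beyond the scatter) and is the first single change with a readable size. This position therefore responds to the group it carries, modestly and toward a weaker inhibitor, for this one change only. Compound 3 stands as a limit and not a number: the limit of > 350000 nM in this assay, at which 1 of the 4 values shown sits.

Going by these compounds, whether an amine or a longer chain such as butyl on this carbon moves the number further stays open. Also open, on these data alone, is whether the same step holds on the core of compound 2.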